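The source may hold more compounds than are shown below. What is called first, only, known or untested is meant among the compounds shown, and "the series" means these compounds.

Of the compounds shown here, three with a shared core have been tested in a functional assay on T47D cells (Homo sapiens) for cytotoxicity, read by CCK-8 assay and cell counting, with a stated time of 2 days; a lower number here means a stronger inhibitor, a higher number a weaker inhibitor. Compound 1 `Oc1ccc(-c2cc(-c3cccs3)nc(-c3ccccc3Cl)c2)cc1` gives 5870 nM in this assay. Compound 2 `Oc1cccc(-c2cc(-c3cccs3)nc(-c3ccccc3Cl)c2)c1` gives 3990 nM, and compound 3 `Oc1cccc(-c2cc(-c3cccc(Cl)c3)nc(-c3cccs3)c2)c1` gives 3410 nM. Moving the hydroxyl on one phenyl ring, a 1.5-fold lower number from compound 1 to compound 2 (0.17 log units; within the scatter), and moving the chlorine on the other phenyl ring, a 1.2-fold lower number from compound 2 to compound 3 (0.07 log units; within the scatter), both stay within the scatter, so the three numbers cannot be told apart with confidence. Compound 2 therefore sits among them with no clear distance to either of the other two.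

Compound 4 `Oc1cccc(-c2cc(-c3ccsc3)nc(-c3ccccc3Cl)c2)c1` has not yet been measured. It differs from compound 2 in one place: thiophen-3-yl in place of thiophen-2-yl on an aromatic carbon. Going by the values given here, no measured step alters the thiophene, so nothing bears directly on this change. The two measured steps, each a shift of a single group around one ring, stayed within the scatter, and a shift of the attachment point of the thiophene is a change of the same kind. The expectation for compound 4 is therefore no step beyond the scatter in this assay, and the estimated value for compound 4 is 4000 nM, with a range from 1500 nM to 10000 nM. The expected step of a 1.0-fold higher number from compound 2 to compound 4 (0.00 log units; within the scatter) is thus essentially flat.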

Compound 4, half-maximal inhibitory concentration: 2440 nM
For compound 4 the middle estimate is 1.6-fold (0.21 log units) above the measured one; low and high end bracket the measured number.
By their numbers in this assay, from the lowest: compounds 4, 3, 2 and 1 (each within the scatter of the next, the first and the last beyond it).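

Placing thiophen-3-yl instead of thiophen-2-yl on the aromatic carbon next to the ring nitrogen gives, in this assay, a 1.6-fold lower number from compound 2 to compound 4 (0.21 log units; within the scatter), so the two numbers cannot be told apart with confidence. The earlier steps shown here moved a group around a phenyl ring, whereas this one changes the atom through which the thiophene joins the shared core, and this rearrangement also produces no step beyond the scatter. The entering and leaving groups have the same heavy atoms and the same counts of hydrogen-bond donors and acceptors, and no measurement shown here explains how closely the two numbers lie.

The compounds shown leave open whether this position would respond to a group that differs in kind, such as a morpholine, a primary amine or a carboxylic acid, since every change so far only rearranges the same atoms. They also leave open whether thiophen-3-yl would give a similar number alongside a 4-hydroxyphenyl group or a 3-chlorophenyl group, or whether replacing the hydroxyl with a methoxy group would matter.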